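Acetyl to pivaloyl on a fused piperazine quinazoline

A few compounds are considered here, and "the series" means these few. Any claim that something is new, unique, unknown or untested is made for them only; others in the source may bear on it.

Measured compounds:
compound 1, `COc1cc2nc(N3CCN(C(C)=O)[C@H]4CCCC[C@H]43)nc(N)c2cc1OC`, 1700 nM
compound 2, `CCCN(CCC)c1nc(N2CCN(C(=O)c3ccco3)[C@@H]3CCCC[C@@H]32)nc2cc(OC)c(OC)cc12`, 58.9 nM

Compound 1 was measured in a functional assay (strain Wistar) for antagonist activity at Alpha-1D adrenergic receptor (Rattus norvegicus), with a stated time of 30 min, in the presence of a further agent that is not named here (a higher number here means weaker binding, a lower number tighter binding), where compound 1 gives 1700 nM, the highest of the two numbers recorded. For the measured compounds named here, the only other measured compound, compound 2, gives 58.9 nM in this assay, a markedly lower number, but compound 2 differs from compound 1 in several places, so no single change can be read from that pair.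

Compound 3, `COc1cc2nc(N3CCN(C(=O)C(C)(C)C)[C@H]4CCCC[C@H]43)nc(N)c2cc1OC`, has not been measured. It differs from compound 1 in one place: tert-butyl in place of methyl on a carbonyl carbon. Going by the values given here, no measured pair shows this change on its own, so its effect has to be estimated. With nothing in the data that isolates this change, the step from compound 1 to compound 3 is expected to be small, with a 1.7-fold lower number from compound 1 to compound 3 (0.23 log units; within the scatter) leaning toward a lower number but quite possibly lying within the scatter of repeated measurements. Compound 3 is therefore expected to give about 1000 nM in this assay, within a range from 300 nM to 3500 nM.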

Compound 3, dissociation constant: 141 nM
Beside the measured number, compound 3's estimate is 7.1-fold (0.85 log units) above it, and the stated range ends above it.
By their numbers in this assay, from the lowest: compound 2; then compound 3; then compound 1.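

In this assay, for the compounds shown here, tert-butyl in place of methyl on a carbonyl carbon, whose other neighbour is an amide-type nitrogen in a ring, gives a 12-fold lower number from compound 1 to compound 3 (1.08 log units; beyond the scatter), a large step and the only change in this set that can be read on its own. It shows that this position on the shared core responds strongly to what stands on the carbonyl, even though the change from acetyl to (tert-butyl)carbonyl swaps carbon for carbon alone, with no ring, hydrogen-bond donor, hydrogen-bond acceptor or net charge entering or leaving. Nothing available here accounts for the size of this step, so it stands as an observation without an explanation.

The compounds shown leave open whether a group such as isopropyl, cyclohexyl or phenyl on the same carbonyl carbon would give a number close to that of compound 1, close to that of compound 3 or one beyond both. They also leave open whether the same step would appear on a core carrying a dimethylamino group in place of the amino group of compound 1.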